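The source may hold more compounds than are shown below. What is called first, only, known or untested is meant among the compounds shown, and "the series" means these compounds.

Of the compounds shown here, three have been tested in a functional assay on MCF7 cells (Homo sapiens) for cytotoxicity, read by MTT assay, with a stated time of 4 days (on this read-out higher numbers stand for weaker inhibition and lower numbers for stronger inhibition), and a fourth is waiting to be. Compound 1 `Cc1c(O)ccc2c1[C@H](Cn1cc(-c3ccccc3)nn1)[C@@]13CC(=O)[C@@](C)(CC[C@@H]21)C3` carries a hydroxy on its aromatic ring. In this assay compound 1 gives only a limit, > 20000 nM. Compound 2 `Cc1ccc(S(=O)(=O)Oc2ccc3c(c2C)[C@H](Cn2cc(-c4ccccc4)nn2)[C@@]24CC(=O)[C@@](C)(CC[C@@H]32)C4)cc1` differs from it by (4-methylphenyl)sulfonyl in place of hydrogen on an oxygen on an aromatic ring. In this assay compound 2 likewise gives only a limit, > 20000 nM. The step between them, a step that the two limits leave unreadable from compound 1 to compound 2, cannot be read, because both values sit at the limit of > 20000 nM in this assay, at which 2 of the 3 values shown sit.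

Compound 3 `C=C1C(=O)[C@]23C[C@@]1(O)CC[C@H]2c1ccc(O)c(C)c1[C@@H]3Cn1cc(-c2ccc(OC)cc2)nn1` is built on a different core; how its core differs from that of compound 1 is not broken down here. In this assay compound 3 gives 1710 nM. Compound 4 `C=C1C(=O)[C@]23C[C@@]1(O)CC[C@H]2c1ccc(OS(=O)(=O)c2ccc(C)cc2)c(C)c1[C@@H]3Cn1cc(-c2ccc(OC)cc2)nn1` is the still unmeasured partner of compound 3, differing from it by (4-methylphenyl)sulfonyl in place of hydrogen on an oxygen on an aromatic ring, the same change as that from compound 1 to compound 2.

Going by the values given here, the one measured instance of this change gives no readable size, so the expectation for compound 4 rests on compound 3 at 1710 nM. In this assay the expected step is a 2.3-fold higher number from compound 3 to compound 4 (0.37 log units; beyond the scatter), a modest loss close to the scatter. Compound 4 is thus estimated to give about 4000 nM, somewhere between 1200 nM and 18000 nM.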

Compound 4, half-maximal inhibitory concentration: 310 nM
Estimate against measurement, compound 4: 13-fold (1.11 log units) above; the measured number lies below the stated range.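

In this assay, the change on the core of compound 3 gives a 5.5-fold lower number from compound 3 to compound 4 (0.74 log units; beyond the scatter), so here replacing hydroxy with ((4-methylphenyl)sulfonyl)oxy goes with stronger inhibition. On the core of compound 1, the size of the same change cannot be read because compound 1 and compound 2 each give only a limit, not a number: the limit of > 20000 nM in this assay, at which 2 of the 4 values shown sit. The series therefore offers a single readable instance of this change, which shows what it does on one core but not whether its effect carries over from one core to another.

The compounds shown leave open whether another group on the same oxygen, such as acetyl or methylsulfonyl, would give a step like that of (4-methylphenyl)sulfonyl. They also leave open whether a core carrying an amine in place of the hydroxy of compound 3 would keep the inhibition seen with compound 3.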